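An Amino Group Enters the Core of Compound 1

This account rests on a few compounds, and the source may have more. Where it says the series, first, only, none or still open, it means among the compounds named here.

Measured so far in a functional assay on HCT-116 cells (Homo sapiens) for cytotoxicity, read by sulforhodamine B assay, with a stated time of 48 h; on this read-out higher numbers stand for lower toxicity in this test and lower numbers for higher toxicity in this test:
- compound 1, `ClCc1cccc(Cn2cnc3c(Cl)ncnc32)c1`, gives 6310 nM.
- compound 2, `ClCc1ccc(Cn2cnc3nc(Cl)nc(Cl)c32)cc1`, gives > 100000 nM, which is a limit of the assay rather than a number.

Among these two results, compound 1 stands as the only value reported as a number; the other result is a limit. For compound 2 the outcome is only the limit described as the limit of > 100000 nM in this assay, at which 1 of the 2 values shown sits. Compound 3, `Nc1nc(Cl)c2ncn(Cc3cccc(CCl)c3)c2n1`, has not yet been measured. It differs from compound 1 in a single place: amino in place of hydrogen on an aromatic carbon. The arm attached to the shared core stays the same in both. Going by the values given here, no pair of measured compounds differs in one place only, so the size of such a step has not been seen here and the expectation rests on the change alone. A modest step toward lower toxicity is expected for a 1.9-fold higher number from compound 1 to compound 3 (0.28 log units; within the scatter), although a step within the scatter would be no surprise. Compound 3 is therefore estimated at 12000 nM, in a range from 3000 nM to 60000 nM.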

Compound 3, concentration lethal to 50% of the cells: 75900 nM
Compound 3: middle estimate off by 6.3-fold (0.80 log units), on the low side, and the stated range ends below it.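

At this position, on an aromatic carbon between two ring nitrogen atoms, putting amino in place of hydrogen gives in this assay a 12-fold higher number from compound 1 to compound 3 (1.08 log units; beyond the scatter) and so moves the read-out clearly toward lower toxicity. Going by these compounds alone, until now no two measured compounds differed in one place only, so the size of such a change was unknown; this pair shows that one added heavy atom on the shared core, with the arm left as it was, can shift the result well past the usual scatter of repeated measurements. Nothing shown here gives a reason for a step of this size.

One group at one position cannot tell whether the large step belongs to amino itself or would also follow from other groups on the same carbon, such as a methylamino group, a hydroxyl group or a fluoro atom. As far as these compounds go, it also remains open whether the same exchange of hydrogen for amino would produce a step of similar size on a compound carrying a different arm, for example one with a longer chain in place of the chloromethyl group.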